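The compounds below may be only part of what the source reports. "The series", "measured", "known", "first", "only" and "open" are said of these compounds alone.

Measured compounds:
compound 1, `Cc1c(C(=O)Nc2ccc(Oc3ccnc4[nH]ccc34)cc2)nnn1-c1ccccc1`, 350 nM
compound 2, `Cc1c(C(=O)Nc2ccc(Oc3ccnc4[nH]ccc34)cc2)nnn1-c1ccc(F)c(F)c1`, 1070 nM
compound 3, `O=C(Nc1ccc(Oc2ccnc3[nH]ccc23)c(F)c1)c1nnn(-c2ccccc2)c1C(F)(F)F`, 91 nM

All three compounds were tested in a functional assay on HT-29 cells (Homo sapiens) for cytotoxicity, read by MTT assay, with a stated time of 72 h; a higher number here means a weaker inhibitor, a lower number a stronger inhibitor. Compound 1 gives 350 nM, and compound 2 gives 1070 nM. The change from compound 1 to compound 2 is 3,4-difluorophenyl in place of phenyl on an aromatic nitrogen, and it produced a 3.1-fold higher number from compound 1 to compound 2 (0.49 log units; beyond the scatter), a step beyond the usual scatter.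

Compound 3 has the lowest number of the three, with 91 nM in this assay. The difference between the core of compound 3 and the core of compound 1 is not broken down here; the two values show that compound 3 sits well below compound 1.

Compound 4, `O=C(Nc1ccc(Oc2ccnc3[nH]ccc23)c(F)c1)c1nnn(-c2ccc(F)c(F)c2)c1C(F)(F)F`, has not been measured. It differs from compound 3 by 3,4-difluorophenyl in place of phenyl on an aromatic nitrogen. For the measured compounds named here, this is the same kind of change as the one from compound 1 to compound 2, though not the same: in compound 1 the ring nitrogen that carries the phenyl is next to the ring atom that bears a methyl group, whereas in compound 3 it is next to the ring atom that bears a trifluoromethyl group.

Resting on the one earlier instance of this change, a 3.1-fold higher number from compound 1 to compound 2 (0.49 log units; beyond the scatter), compound 4 is expected to show a step of about a 3.0-fold higher number from compound 3 to compound 4 (0.47 log units; beyond the scatter) in this assay. Going by the values given here, the estimate for compound 4 in this assay is therefore 270 nM, with a plausible range from 120 nM to 600 nM, the width reflecting that only one earlier example of this change is known and that the surroundings of the place differ.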

Compound 4, half-maximal inhibitory concentration: 320 nM
Beside the measured number, compound 4's estimate is 1.2-fold (0.07 log units) below it; low and high end bracket the measured number.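

In this assay, placing 3,4-difluorophenyl instead of phenyl on the aromatic nitrogen again made the inhibitor weaker, with a 3.5-fold higher number from compound 3 to compound 4 (0.55 log units; beyond the scatter), so the loss seen on the methyl-bearing core also appears on the trifluoromethyl-bearing core. The size of the step carries over between these two cores within the scatter: the same change on two cores in this assay, a 3.1-fold higher number (0.49 log units; beyond the scatter) from compound 1 to compound 2 and a 3.5-fold higher number (0.55 log units; beyond the scatter) from compound 3 to compound 4, 1.2-fold (0.06 log units) apart, within the scatter of two such steps This is still only two instances in a single cell assay, so it does not show that the step would hold on other cores, and it gives no reason for the loss, nor does it show which of the two fluorine atoms contributes to it.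

The compounds shown leave open whether a single fluorine on the phenyl would give all, part or none of this step, and how a chlorine, a methoxy group or an amine would read on that ring. They also leave open whether the step would persist if an ethyl chain or a carboxylic acid stood in place of the methyl or trifluoromethyl group on the ring that carries the nitrogen substituent.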